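Cytotoxicity of Three Anilides and an Expectation for Compound 4

This account rests on a few compounds, and the source may have more. Where it says the series, first, only, none or still open, it means among the compounds named here.

Measured in an ADME assay on NCM460 cells (Homo sapiens) for cytotoxicity, read by MTT assay, with a stated time of 72 h (on this read-out lower numbers stand for stronger inhibition and higher numbers for weaker inhibition), each value being a limit of the assay rather than a number:
- compound 1 `CCCCCN1C(=O)C/C(=C\c2cccc(C(=O)Nc3ccc(C)cc3)c2)C1=O`: > 100000 nM
- compound 2 `O=C(Nc1ccccc1)c1cccc(/C=C2\CC(=O)N(c3ccccc3)C2=O)c1`: > 100000 nM
- compound 3 `COc1ccc(NC(=O)c2cccc(/C=C3\CC(=O)N(c4ccc(C)cc4)C3=O)c2)cc1`: > 100000 nM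

For the measured compounds named here, compound 2 therefore sits at the limit of > 100000 nM in this assay, at which 3 of the 3 values shown sit, and nothing measured so far separates it from its two companions, since each is a limit only. Compound 4 `COc1ccc(OC)c(NC(=O)c2cccc(/C=C3\CC(=O)N(c4ccccc4)C3=O)c2)c1` differs from compound 2 by 2,5-dimethoxyphenyl in place of phenyl on an amide-type nitrogen. Going by the values given here, no measured pair shows a step in this assay, so the expected change from compound 2 to compound 4 is none beyond the scatter, with a chance that compound 4 again reaches only the limit. The estimate for compound 4 is 100000 nM, expected to lie between 50000 nM and 300000 nM. The step from compound 2 to compound 4 that this estimate means is expected to be a number no higher from compound 2 to compound 4 (the limit leaves the size open).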

Compound 4, half-maximal inhibitory concentration: > 100000 nM
Compound 4: only a limit was reported; the forecaster's own chance of this, stated with the estimate: 80%; the middle value lies on the limit itself.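

In this assay compound 4 gives > 100000 nM, which is a limit and not a number. For the compounds shown here, compound 2 also has only a limit, so no step between compound 2 and compound 4 can be read. The compounds shown leave open whether 2,5-dimethoxyphenyl in place of phenyl changes the value at all.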